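Methylphenyl in Place of Aminophenyl on the Shared Core

The compounds below may be only part of what the source reports. "The series", "measured", "known", "first", "only" and "open" are said of these compounds alone.

Compound 3 `Cc1c(NCc2nnc(-c3ccc(N)cc3)o2)c(=O)n(-c2ccccc2)n1C` stands second highest of the three compounds measured in a physicochemical assay for lipophilicity, measured as octanol-water partition (a lower number here means a more polar compound, a higher number a more lipophilic compound), where compound 3 gives 1.13. Compound 1 `Cc1c(NCc2nnc(COc3ccccc3)o2)c(=O)n(-c2ccccc2)n1C` gives 0.98 in this assay, and the step of a number 0.15 log units higher from compound 1 to compound 3 (within the scatter) leaves the two within the scatter of each other. Compound 2 `Cc1cccc(-c2nnc(CNc3c(C)n(C)n(-c4ccccc4)c3=O)o2)c1` gives 2.39, and the step of a number 1.26 log units lower from compound 2 to compound 3 (beyond the scatter) separates it clearly from compound 3. Compound 4 `Cc1ccccc1-c1nnc(CNc2c(C)n(C)n(-c3ccccc3)c2=O)o1` differs from compound 3 by 2-methylphenyl in place of 4-aminophenyl on an aromatic carbon. The step that bears most on this is a number 1.26 log units lower from compound 2 to compound 3 (beyond the scatter), the same exchange run in the opposite direction, except that the methyl now sits in a 2-methylphenyl rather than a 3-methylphenyl. The step of a number 1.41 log units higher from compound 1 to compound 2 (beyond the scatter) points the same way, a large rise when a methylphenyl enters. A large upward step, a number 1.22 log units higher from compound 3 to compound 4 (beyond the scatter), is therefore expected for compound 4. Compound 4 is estimated at 2.35, with a range from 1.95 to 2.75.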

Compound 4, partition coefficient: 2.38
Compound 4: middle estimate off by 0.03 log units, on the low side; measured number inside the range.
By their numbers in this assay, from the lowest: compounds 1 and 3 (each within the scatter of the next); then compounds 4 and 2 (each within the scatter of the next).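

In this assay, going by these compounds alone, the step of a number 0.01 log units lower from compound 2 to compound 4 (within the scatter) shows that 2-methylphenyl and 3-methylphenyl cannot be told apart on this aromatic carbon, a comparison the earlier compounds could not offer. The large rise seen earlier with 3-methylphenyl therefore recurs with the second methylphenyl group, in the step of a number 1.25 log units higher from compound 3 to compound 4 (beyond the scatter) from the 4-aminophenyl compound and in the step of a number 1.40 log units higher from compound 1 to compound 4 (beyond the scatter) from the phenoxymethyl compound. Among these four compounds, the two methylphenyl compounds thus form one pair and the 4-aminophenyl and phenoxymethyl compounds another.

Nothing given here explains the separation between these pairs. Also open, on these data alone, is where an unsubstituted phenyl, a carboxylic acid or a longer alkyl chain on the same carbon would fall relative to the two pairs.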